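From Furan-2-yl to Furan-3-yl at an Assay Limit

The source may hold more compounds than are shown below. What is called first, only, known or untested is meant among the compounds shown, and "the series" means these compounds.

Compound 1 `Cc1ncnc2c1c(-c1cc3ccccc3o1)cn2[C@@H]1O[C@H](CO)[C@@H](O)[C@H]1O`: 17300 nM
Compound 2 `Nc1nc(N)c2c(-c3ccco3)cn([C@@H]3O[C@H](CO)[C@@H](O)[C@H]3O)c2n1`: > 20000 nM (a limit)
Compound 3 `Cc1nc(N)c2c(-c3ccco3)cn([C@@H]3O[C@H](CO)[C@@H](O)[C@H]3O)c2n1`: > 100000 nM (a limit)

In a functional assay on CCRF-CEM cells (Homo sapiens), read by MTT assay, with a stated time of 72 h (a lower number here means a stronger inhibitor, a higher number a weaker inhibitor), compound 3 has no number, only the limit > 100000 nM. Compound 2 also has only a limit, > 20000 nM. Of the three, only compound 1 has a number, 17300 nM.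

Compound 4 `Cc1nc(N)c2c(-c3ccoc3)cn([C@@H]3O[C@H](CO)[C@@H](O)[C@H]3O)c2n1` has the same atoms as compound 3, joined differently: furan-3-yl in place of furan-2-yl on an aromatic carbon. The change is furan-3-yl in place of furan-2-yl on an aromatic carbon.

For the measured compounds named here, only one measured step links two compounds by a single change, a step that the two limits leave unreadable from compound 2 to compound 3. That step is a different change, methyl in place of amino, and its size cannot be read. No measured step exchanges one furan for the other, so the data give no reason to expect a shift in either direction. The expected step is a number no higher from compound 3 to compound 4 (the limit leaves the size open), with nothing expected beyond the scatter, and another limit is the likeliest report. For compound 4 the estimate is 100000 nM, with an expected range from 25000 nM to 200000 nM.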

Compound 4, half-maximal inhibitory concentration: > 100000 nM
Compound 4 was reported as a limit; the forecaster's own chance of this, stated with the estimate: 70%; the middle value lies on the limit itself.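

In this assay, compound 3 and compound 4 are both reported only as limits, and the step between them cannot be read. The compounds shown leave open whether furan-3-yl in place of furan-2-yl changes the result at all.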